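Carbamate in place of urea: from compound 3 to compound 4

This account rests on a few compounds, and the source may have more. Where it says the series, first, only, none or still open, it means among the compounds named here.

Of the compounds shown here, three have been measured in a functional assay on cells (Neuronal cell line, Homo sapiens) for inhibition; on this read-out higher numbers stand for weaker inhibition and lower numbers for stronger inhibition. Compound 1 `COC(=O)/C(=C/Cn1c(-c2ccccc2)ncc(NC(=O)OCc2ccccc2)c1=O)COC(=O)c1ccccc1` gives 2.6 ug/mL, and compound 2 `COC(=O)/C(=C/Cn1c(-c2ccccc2)ncc(NC(=O)OCc2ccccc2)c1=O)COC(=O)c1ccc([N+](=O)[O-])cc1`, which carries a nitro group, gives 1.75 ug/mL; the step of a 1.5-fold lower number from compound 1 to compound 2 (0.17 log units; within the scatter) lies within the scatter. Compound 3 `COC(=O)/C(=C/Cn1c(-c2ccccc2)ncc(NC(=O)N2CCN(C(C)=O)CC2)c1=O)COC(C)=O` gives 13.8 ug/mL, the highest of the three numbers and beyond the scatter away from both others.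

Compound 4 `COC(=O)/C(=C/Cn1c(-c2ccccc2)ncc(NC(=O)OCc2ccccc2)c1=O)COC(C)=O` is made from compound 3 by one change: benzyloxy in place of 4-acetylpiperazin-1-yl on a carbonyl carbon. For the measured compounds named here, no measured pair shows this same change, so the one measured step, which concerns a nitro group on a different part of the molecule, does not bear on it. What can be said is that compound 3 differs from compound 1 in two places, this one and the ester on the side chain, and that compounds 1 and 2, both carrying the benzyloxycarbonyl group, sit well below compound 3. Compound 4 is therefore expected to move towards those numbers, a step of a 3.1-fold lower number from compound 3 to compound 4 (0.49 log units; beyond the scatter). Compound 4 is estimated at 4.5 ug/mL, within a range from 1.5 ug/mL to 13 ug/mL.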

Compound 4, half-maximal inhibitory concentration: 0.92 ug/mL
For compound 4 the middle estimate is 4.9-fold (0.69 log units) above the measured one; measured number outside the range, below it.
By their numbers in this assay, from the lowest: compounds 4, 2 and 1 (each within the scatter of the next, the first and the last beyond it); then compound 3.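

Benzyloxy in place of 4-acetylpiperazin-1-yl on the carbonyl carbon gives a 15-fold lower number from compound 3 to compound 4 (1.18 log units; beyond the scatter) in this assay and, with the acetate side chain held constant, shows that this single change is large. The ester on the side chain counts for less: methyl in place of phenyl gives a 2.8-fold lower number from compound 1 to compound 4 (0.45 log units; beyond the scatter) and methyl in place of 4-nitrophenyl gives a 1.9-fold lower number from compound 2 to compound 4 (0.28 log units; within the scatter) so the acetate loses no ground to either aromatic ester. Nothing measured here accounts for any of these steps.

On these data alone, how a simple ethoxy group or a plain amine on this carbonyl carbon would compare stays open, so the part played by the aromatic ring of benzyloxy is unknown. Also open, as far as these compounds go, is what a carboxylic acid in place of the methyl ester would do.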